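Benzylamino in Place of Phenoxy on a Shared Core

The source may hold more compounds than are shown below. What is called first, only, known or untested is meant among the compounds shown, and "the series" means these compounds.

Compound 1 `CCOC(=O)[C@H](CCC(=O)O)NC(=O)c1ccc(Sc2nc3cc(N)cc(N)c3nc2-c2ccccc2)cc1`: 35500 nM
Compound 2 `Nc1cc(N)c2nc(-c3ccccc3)c(Oc3ccc(F)cc3)nc2c1`: 28800 nM
Compound 3 `COc1cc(CNc2nc3cc(N)cc(N)c3nc2-c2ccccc2)cc(OC)c1OC`: 15100 nM

Of the compounds shown here, three sharing one core have been measured in a functional assay on MDA-MB-231 cells (Homo sapiens) for inhibition, read by sulforhodamine B assay, with a stated time of 48 h; on this read-out lower numbers stand for stronger inhibition of growth and higher numbers for weaker inhibition of growth. Compound 2 stands second highest of the three numbers; its nearest neighbour is compound 1, and even the gap to compound 3 stays within the scatter, so no order can be drawn among them. The unmeasured compound 4 `Nc1cc(N)c2nc(-c3ccccc3)c(NCc3ccc(F)cc3)nc2c1` differs from compound 2 in one place: (4-fluorobenzyl)amino in place of 4-fluorophenoxy on an aromatic carbon. Within the data shown here, no step between measured compounds that differ in one place is known here. Since compound 2 gives 28800 nM while compound 3 gives 15100 nM, only a small step toward a lower number, or none beyond the scatter, is expected. Compound 4 is estimated at 18000 nM, ranging from 6000 nM to 55000 nM. That estimate would mean a 1.6-fold lower number from compound 2 to compound 4 (0.20 log units; within the scatter) in this assay.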

Compound 4, concentration for total growth inhibition: 5130 nM
The estimate for compound 4 lay 3.5-fold (0.55 log units) above the measured number; the whole stated range lies above it.
By their numbers in this assay, from the lowest: compound 4; then compounds 3, 2 and 1 (each within the scatter of the next, the first and the last beyond it).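

In this assay, among these compounds, the change from 4-fluorophenoxy to (4-fluorobenzyl)amino, on the aromatic carbon next to the ring nitrogen and ortho to a phenyl group, gives a 5.6-fold lower number from compound 2 to compound 4 (0.75 log units; beyond the scatter) and is the first step at this position. The earlier compounds shown here differed in more than one place, so they gave no such step. Nothing measured here explains it.

The compounds shown leave open whether a 4-fluoroanilino group or an N-methyl-(4-fluorobenzyl)amino group at this position would give a comparable number, and whether an unsubstituted benzylamino group would.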